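A few compounds are considered here, and "the series" means these few. Any claim that something is new, unique, unknown or untested is made for them only; others in the source may bear on it.

Three compounds share a common core and a long unsaturated chain. Compound 1 `CC/C=C\C/C=C\C/C=C\CCCCCCCc1cc(=O)c2c(O)c(C)c(OCOC)c(C)c2o1` carries a protected hydroxyl on the core, compound 2 `CC/C=C\C/C=C\C/C=C\CCCCCCCC1(O)CC(=O)c2c(O)c(C)c(O)c(C)c2O1` has a saturated, hydroxylated ring in place of the aromatic one, and compound 3 `CC/C=C\C/C=C\C/C=C\CCCCCCCc1cc(=O)c2c(O)cc(O)c(C)c2o1` lacks one of the methyl groups. In a functional assay on MDA-MB-231 cells (Homo sapiens) for antiproliferative activity, read by MTT assay (on this read-out lower numbers stand for stronger inhibition and higher numbers for weaker inhibition), compound 1 gives 16100 nM, compound 2 gives 42800 nM and compound 3 gives 6790 nM. Compound 2 thus stands highest of the three, its nearest neighbour being compound 1 and its furthest compound 3, both gaps lying beyond the usual scatter.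

Compound 4 `CCCCC/C=C\C/C=C\CCCCCCCC1(O)CC(=O)c2c(O)c(C)c(O)c(C)c2O1` differs from compound 2 only in the chain: butyl in place of but-1-en-1-yl on a saturated chain carbon bound to a double-bonded chain carbon. One double bond outside aromatic rings leaves and nothing else is counted. Within the data shown here, no measured pair shows what such a change does here, so the expectation rests on the chain being far from the core. The step from compound 2 to compound 4 is expected to be small, a 1.1-fold lower number from compound 2 to compound 4 (0.03 log units; within the scatter), likely within the scatter. Compound 4 is therefore estimated at 40000 nM, with a range from 15000 nM to 100000 nM.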

Compound 4, half-maximal inhibitory concentration: 42800 nM
Beside the measured number, compound 4's estimate is 1.1-fold (0.03 log units) below it; measured number inside the range.
By their numbers in this assay, from the lowest: compound 3; then compound 1; then compounds 2 and 4 (each within the scatter of the next).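

In this assay, among these compounds, the swap of but-1-en-1-yl for butyl gives no change at the digits printed from compound 2 to compound 4 (within the scatter) and this is the first pair that differs in one place, so it is the first direct reading of a change in the chain. For this pair, losing one double bond outside aromatic rings, on a saturated chain carbon bound to a double-bonded chain carbon, leaves the antiproliferative number where it was. Nothing available here explains this outcome.

Going by these compounds, whether the same swap would also leave the number unchanged on the core of compound 1 or the core of compound 3 remains open. Also open, on these data alone, is what a fully saturated chain, a much shorter chain, or a chain ending in a carboxylic acid or an amine would do to the number.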